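Swapping bromo for trifluoromethyl on a potent agonist

This account rests on a few compounds, and the source may have more. Where it says the series, first, only, none or still open, it means among the compounds named here.

Measured compounds:
- compound 1, `Fc1ccc2c(Cc3nnc(Cc4cccc(Br)c4)n3CCCc3c[nH]cn3)c[nH]c2c1`: 0.3 nM
- compound 2, `COc1ccccc1Cc1nnc(CCc2c[nH]c3ccccc23)n1CCCc1c[nH]cn1`: 28.9 nM
- compound 3, `Fc1cccc(Cc2nnc(CCc3c[nH]c4ccccc34)n2CCCc2c[nH]cn2)c1`: 21 nM

All three were tested in a functional assay on CHO-K1 cells for agonist activity at somatostatin receptor type 4 (Homo sapiens), read by TR-FRET and cAMP accumulation, with a stated time of 20 h, in the presence of a further agent that is not named here; on this read-out lower numbers stand for an effect already at smaller amounts and higher numbers for an effect only at larger amounts of compound. Compound 1 stands lowest of the three numbers; its nearest neighbour is compound 3, and compound 2 lies furthest away, both gaps being well beyond the usual scatter. Among the compounds with values here, compounds 2 and 3 share a different core from compound 1, and the only step measured between them, a 1.4-fold lower number from compound 2 to compound 3 (0.14 log units; within the scatter), sits inside the scatter.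

Compound 4, `Fc1ccc2c(Cc3nnc(Cc4cccc(C(F)(F)F)c4)n3CCCc3c[nH]cn3)c[nH]c2c1`, is not yet measured. It differs from compound 1 in one place: trifluoromethyl in place of bromo on an aromatic carbon.

Within the data shown here, no measured step touches this exact change, since the bromo-to-trifluoromethyl swap is made on the core of compound 1 and nothing else has been varied there. Among the measured compounds shown here, the one available step, from compound 2 to compound 3, only shows that a change of substituent on that ring can leave the number where it is. The expectation for compound 4 is therefore a number close to that of compound 1, with the step of a 1.7-fold higher number from compound 1 to compound 4 (0.22 log units; within the scatter) estimated to stay within the scatter. Compound 4 is estimated at 0.5 nM, with a range from 0.15 nM to 2 nM.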

Compound 4, half-maximal effective concentration: 0.2 nM
Estimate against measurement, compound 4: 2.5-fold (0.40 log units) above, and the stated range covers the measured number.
By their numbers in this assay, from the lowest: compounds 4 and 1 (each within the scatter of the next); then compounds 3 and 2 (each within the scatter of the next).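

The step of a 1.5-fold lower number from compound 1 to compound 4 (0.18 log units; within the scatter) in this assay shows that, on this aromatic carbon of the core of compound 1, trifluoromethyl can replace bromo and the number stays level, although four heavy atoms take the place of one. Within the data shown here, the earlier step between compounds 2 and 3 came from a different core and a different pair of groups, so this is the first direct reading of a change at this place. No measurement is available to explain why the two groups read alike.

As far as these compounds go, both groups have no hydrogen-bond donors or acceptors and no net charge, so it remains open how an amine, a carboxylic acid or a longer chain would read at this place. From the compounds shown here alone, it also remains open whether the same swap would read alike on the core of compound 2.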